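The source may report more compounds than this note shows. Statements on the series, on what has been measured and on what is new or still open speak of the compounds shown alone.

Measured so far:
compound 1 `CC/C=C\[C@H](C)[C@H](OC(N)=O)[C@@H](C)[C@H](O)[C@@H](C)C/C(C)=C\[C@H](C)[C@@H](O)[C@@H](C)/C=C\[C@@H](O)C[C@@H]1OC(=O)[C@H](C)C[C@H]1C` — 50 nM
compound 2 `CC/C=C\[C@H](C)[C@H](OC(N)=O)[C@@H](C)[C@H](O)[C@@H](C)C/C(C)=C\[C@H](C)[C@@H](O)[C@@H](C)/C=C\[C@@H](O)C[C@H](O)[C@H](C)C[C@H](C)C(=O)OC` — 4000 nM

Compound 1 gives the lowest number of the two in a functional assay on A549 cells (Homo sapiens) for antiproliferative activity; a higher number here means a weaker inhibitor of growth, a lower number a stronger inhibitor of growth; the nearest value is that of compound 2, reached by an 80-fold higher number from compound 1 to compound 2 (1.90 log units; beyond the scatter), a large step beyond the scatter. For the measured compounds named here, that step replaces the whole six-membered lactone region with an open chain and is the only measured step in the set.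

Compound 3 `CC/C=C\[C@H](C)[C@H](OC(N)=O)[C@@H](C)[C@H](O)[C@@H](C)C/C(C)=C\[C@H](C)[C@@H](O)[C@@H](C)/C=C\[C@@H](O)C[C@@H]1OC(=O)[C@H](C)[C@@H](OC)[C@H]1C` keeps the shared core of compound 1 and differs by methoxy in place of hydrogen on a saturated ring carbon. Going by the values given here, no measured step covers the addition of a methoxy group at this position; the step from compound 1 to compound 2 concerns a different change and so gives no direct guide. Without a comparable step, the expectation for compound 3 is a step of modest size at most, a 1.6-fold higher number from compound 1 to compound 3 (0.20 log units; within the scatter), most likely within the scatter. Compound 3 is therefore estimated at 80 nM in this assay, with a range of 25 nM to 300 nM.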

Compound 3, concentration for 50% growth inhibition: 12 nM
For compound 3 the middle estimate is 6.7-fold (0.82 log units) above the measured one; the measured number lies below the stated range.
By their numbers in this assay, from the lowest: compound 3; then compound 1; then compound 2.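

In this assay the saturated ring carbon next to two ring atoms that each bear a methyl group accepts a methoxy group in place of hydrogen without loss, and the change gives a 4.2-fold lower number from compound 1 to compound 3 (0.62 log units; beyond the scatter), so this position can raise growth inhibition in the series. The open-chain compound 2 lies far from the methoxy-bearing ring, with a 330-fold lower number from compound 2 to compound 3 (2.52 log units; beyond the scatter), but that step exchanges the open chain for the ring and adds the methoxy in one move, so it does not separate the two changes. Nothing at hand accounts for the gain from methoxy.

Still open, from the compounds shown here alone, is whether the gain is particular to methoxy or carries over to a hydroxyl or an ethoxy group on the same ring carbon. Also open, going by these compounds, is how the opposite configuration at that carbon would compare.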